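From Pyridin-2-yl to 3-Chlorophenyl: An Expected Step

A few compounds are considered here, and "the series" means these few. Any claim that something is new, unique, unknown or untested is made for them only; others in the source may bear on it.

Compound 1 `COC(=O)/C=C/c1cccc(N(Cc2ccc(/C=C/c3ccccn3)cc2)C(=O)C(C)C)c1` was measured in an assay on isolated protein with Bile acid receptor (Homo sapiens) as the target (on this read-out lower numbers stand for an effect already at smaller amounts and higher numbers for an effect only at larger amounts of compound), and gave 310 nM. Compound 2 `COC(=O)/C=C/c1cccc(N(Cc2ccc(/C=C/C(=O)OC(C)(C)C)cc2)C(=O)c2ccccc2)c1` gave 236 nM in this assay; compound 1 holds the higher of the two numbers, yet the gap to compound 2 lies within the scatter, so the two values show no difference. Compound 3 `COC(=O)/C=C/c1cccc(N(Cc2ccc(/C=C/c3cccc(Cl)c3)cc2)C(=O)C(C)C)c1` awaits measurement and differs from compound 1 in one place: 3-chlorophenyl in place of pyridin-2-yl on a double-bonded chain carbon bound to a double-bonded chain carbon. Among the compounds with values here, no measured pair shows this change, so the step from compound 1 to compound 3 is expected at a 1.2-fold lower number from compound 1 to compound 3 (0.08 log units; within the scatter), little if anything beyond the scatter. Compound 3 is estimated at 260 nM, with a range from 80 nM to 900 nM.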

Compound 3, half-maximal effective concentration: 164 nM
The estimate for compound 3 lay 1.6-fold (0.20 log units) above the measured number, and the stated range covers the measured number.
By their numbers in this assay, from the lowest: compounds 3, 2 and 1 (each within the scatter of the next).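

On a double-bonded chain carbon bound to a double-bonded chain carbon, 3-chlorophenyl in place of pyridin-2-yl gives a 1.9-fold lower number from compound 1 to compound 3 (0.28 log units; within the scatter) in this assay and so shows no difference. At this place, a carbon-only ring bearing chlorine can therefore stand in for a ring with one hetero atom without moving the number beyond the scatter. Nothing at hand gives a cause for this reading. From the compounds shown here alone, it remains open whether a carboxylic acid, an amine or 4-chlorophenyl at this place would shift the number beyond the scatter.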